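The source may report more compounds than this note shows. Statements on the series, on what has been measured and on what is new or still open speak of the compounds shown alone.

Measured compounds:
- compound 1 `CCOC(=O)C1CCN(C(=O)CN2CN(c3ccccc3)C3(CCN(C(=O)c4ccc(C5CCCCC5)cc4)CC3)C2=O)CC1`: 900 nM
- compound 2 `CC(C)(C)OC(=O)NCCCCCNC(=O)CN1CN(c2ccccc2)C2(CCN(C(=O)c3ccc(C(C)(C)C)cc3)CC2)C1=O`: 13700 nM
- compound 3 `CCc1nn(CC)c(C2CCN(C(=O)CN3CN(c4ccccc4)C4(CCN(C(=O)c5ccc(C(C)(C)C)cc5)CC4)C3=O)CC2)c1C`: 2500 nM

Of the compounds shown here, three sharing one core have been tested in an assay on HEK293 cells for displacement of a labelled ligand from NPC1-like intracellular cholesterol transporter 1 (Homo sapiens); on this read-out lower numbers stand for stronger inhibition and higher numbers for weaker inhibition. Compound 1 gives 900 nM and compound 3 gives 2500 nM, while compound 2 gives 13700 nM, the highest of the three numbers and therefore the weakest displacement shown; its distance to compound 3 and to compound 1 lies beyond the usual scatter in each case.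

Compound 4 `CC(C)(C)c1ccc(C(=O)N2CCC3(CC2)C(=O)N(CC(=O)NCCCCO)CN3c2ccccc2)cc1` is not yet measured. It differs from compound 2 in one place: hydroxy in place of ((tert-butoxycarbonyl)amino)methyl on a saturated chain carbon, four bonds along the chain from an amide-type nitrogen. The long protected chain of compound 2 is thus cut back to a shorter chain ending in a hydroxy group.

Within the data shown here, no pair of measured compounds differs in just one place, so nothing shows directly how such a cut plays out in this assay. Compound 2 is the weakest of the three, so there is room to move toward the other two. The step from compound 2 to compound 4 is expected to be a 1.7-fold lower number from compound 2 to compound 4 (0.23 log units; within the scatter), a modest gain. Compound 4 is expected to give 8000 nM, within a range from 2500 nM to 25000 nM.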

Compound 4, half-maximal inhibitory concentration: 19200 nM
Compound 4: the middle estimate sits 2.4-fold (0.38 log units) below what was measured; the range from low to high includes it.
By their numbers in this assay, from the lowest: compound 1; then compound 3; then compounds 2 and 4 (each within the scatter of the next).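

In this assay, the exchange of ((tert-butoxycarbonyl)amino)methyl for hydroxy on a saturated chain carbon, four bonds along the chain from an amide-type nitrogen, gives a 1.4-fold higher number from compound 2 to compound 4 (0.15 log units; within the scatter). Among these compounds, this is the first direct comparison at this position, and it shows that a group of 9 heavy atoms can give way to one of 1 heavy atom with no change that stands out from the scatter. Nothing measured here bears on why the two compounds read alike.

As far as these compounds go, whether an amine or a carboxylic acid at the end of this chain would read differently remains open. Compound 4 also differs from compound 2 in both chain length and end group, so these two compounds cannot separate the contribution of each.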